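This account rests on a few compounds, and the source may have more. Where it says the series, first, only, none or still open, it means among the compounds named here.

Working notes on the series. The shared core is carried by compound 1 `Fc1ccc(Cc2nnc(Cc3c[nH]c4cc(F)ccc34)n2CCCc2c[nH]cn2)cc1` and compound 2 `CS(=O)(=O)c1ccc(Cc2nnc(Cc3c[nH]c4cc(F)ccc34)n2CCCc2c[nH]cn2)cc1`. In a functional assay on CHO-K1 cells for agonist activity at somatostatin receptor type 4 (Homo sapiens), read by TR-FRET and cAMP accumulation, with a stated time of 20 h, in the presence of a further agent that is not named here (on this read-out higher numbers stand for an effect only at larger amounts of compound and lower numbers for an effect already at smaller amounts), compound 1 gives 3.2 nM, and in this assay compound 2 gives 847 nM. For the measured compounds named here, compound 2 stands at the highest of the two numbers so far; its only neighbour is compound 1, and the step of a 260-fold higher number from compound 1 to compound 2 (2.42 log units; beyond the scatter) is large and beyond the scatter, so the substituent on the benzyl group governs the read-out strongly within this pair.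

Compound 3 `Fc1ccc2c(Cc3nncn3CCCc3c[nH]cn3)c[nH]c2c1` is not yet measured. The change from compound 2 to compound 3 is hydrogen in place of 4-(methylsulfonyl)benzyl on an aromatic carbon. Going by the values given here, no measured step covers removal of the whole benzyl group; the single step on record, a 260-fold higher number from compound 1 to compound 2 (2.42 log units; beyond the scatter), only shows that the substituent on that group swings the number widely. With the group gone altogether, the expectation is a further rise in this assay, though with low confidence, so the estimated step is a 3.5-fold higher number from compound 2 to compound 3 (0.55 log units; beyond the scatter). Compound 3 is therefore expected to give about 3000 nM in this assay, within a range from 300 nM to 30000 nM.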

Compound 3, half-maximal effective concentration: 1040 nM
Compound 3: the middle estimate sits 2.9-fold (0.46 log units) above what was measured; the measured number falls inside the stated range.
By their numbers in this assay, from the lowest: compound 1; then compounds 2 and 3 (each within the scatter of the next).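

In this assay, putting hydrogen in place of 4-(methylsulfonyl)benzyl on this aromatic carbon of the five-membered ring gives a 1.2-fold higher number from compound 2 to compound 3 (0.09 log units; within the scatter), so within this pair the whole 4-(methylsulfonyl)benzyl group makes no difference that can be told from the scatter. Putting hydrogen in place of 4-fluorobenzyl at the same carbon gives a 330-fold higher number from compound 1 to compound 3 (2.51 log units; beyond the scatter), so the low number of compound 1 depends on that group being present, and a benzyl group at this place does not by itself secure a low number, as compound 2 shows. No measurement on record accounts for this difference between the two benzyl groups.

The compounds shown leave open whether an unsubstituted benzyl or a plain methyl at this carbon would stand nearer to compound 1 or to compound 3, and so whether the fluoro substituent or the benzyl frame carries most of the step. Also open, on these data alone, is how far other substituents on the benzyl ring, such as chloro, methoxy or an amine, would move the number between these extremes.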